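Replacing the bromoindole acyl group in a hydrazone series

The compounds below may be only part of what the source reports. "The series", "measured", "known", "first", "only" and "open" are said of these compounds alone.

Compound 1 `COc1ccc2c(c1)c(/C=N\NC(=O)c1c[nH]c3ccc(Br)cc13)cn2Cc1ccc(Cl)cc1` is the starting point of this comparison. In a functional assay on LNCaP cells (Homo sapiens) for cytotoxicity (on this read-out higher numbers stand for weaker inhibition and lower numbers for stronger inhibition), compound 1 gives only a limit of the assay, > 100000 nM, and not a number. Compound 3 `COc1ccc(Cn2cc(/C=N\NC(=O)c3c[nH]c4ccccc34)c3cc(OC)ccc32)cc1` also reaches only the limit of this assay, > 100000 nM. Within the data shown here, compound 2 `O=C(N/N=C\c1cn(Cc2ccc(Cl)cc2)c2ccc(Br)cc12)c1c[nH]c2ccccc12` is the one member of the set with a measured number in this assay, 3700 nM. Among the measured compounds shown here, compound 1 therefore sits at the limit of > 100000 nM in this assay, at which 2 of the 3 values shown sit, and no step between two measured compounds of the set is available to calibrate the change that follows.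

Compound 4 `COc1ccc2c(c1)c(/C=N\NC(=O)c1cn(C)c3ccccc13)cn2Cc1ccc(Cl)cc1` has not yet been measured in this assay. Compared with compound 1, it carries 1-methyl-1H-indol-3-yl in place of 5-bromo-1H-indol-3-yl on a carbonyl carbon. Compound 2, with its measured value, differs from compound 1 in more than one place, so its number does not fix the size of this single change. With compound 1 at the limit, the expected step of an at least 1.2-fold lower number from compound 1 to compound 4 (0.09 log units; that floor lies within the scatter) is small and could fall either way, and it is expected to remain largely within the scatter. Compound 4 is therefore estimated at 80000 nM, within a range from 15000 nM to 300000 nM, with a considerable chance that this assay again returns only a limit.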

Compound 4, half-maximal inhibitory concentration: > 100000 nM
Compound 4 was reported as a limit; the forecaster's own chance of this, stated with the estimate: 60%; at least 1.2-fold (0.09 log units) between middle value and limit.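

In this assay compound 4, like compound 1, gives only a limit and not a number, so no step between the two can be read: the limit of > 100000 nM in this assay, at which 3 of the 4 values shown sit.

The compounds shown leave open whether 1-methyl-1H-indol-3-yl in place of 5-bromo-1H-indol-3-yl on a carbonyl carbon changes the read-out at all, and in which direction.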